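Acyl to sulfonyl swap on the ring nitrogen

The compounds below may be only part of what the source reports. "The series", "measured", "known", "first", "only" and "open" are said of these compounds alone.

Measured compounds:
compound 1 `CN(C)c1ccc(C2CC(c3ccc(-n4ccnc4)cc3)=NN2)cc1`, -20.9%
compound 2 `CN(C)c1ccc(C2CC(c3ccc(-n4ccnc4)cc3)=NN2C(=O)c2ccc(C(F)(F)F)cc2)cc1`, 28%

In a functional assay on HCC1806 cells (Homo sapiens) for inhibition, read by sulforhodamine B assay, tested at 10 uM (a lower number here means less inhibition, a higher number more inhibition at the concentration tested (going by the name of the read-out)), compound 1 gives -20.9%, while compound 2 gives 28%, the higher of the two numbers. Within the data shown here, the single measured step, a number 48.9 percentage points higher from compound 1 to compound 2 (beyond the scatter), came from placing (4-(trifluoromethyl)phenyl)carbonyl where compound 1 carries hydrogen on an amine nitrogen in a ring; it shows that substitution at that position raised inhibition well beyond the scatter.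

Compound 3 `CN(C)c1ccc(C2CC(c3ccc(-n4ccnc4)cc3)=NN2S(=O)(=O)c2ccc([N+](=O)[O-])cc2)cc1` differs from compound 2 as follows: (4-nitrophenyl)sulfonyl in place of (4-(trifluoromethyl)phenyl)carbonyl on an amine nitrogen in a ring. Among the measured compounds shown here, no measured step covers an exchange of one substituent on that nitrogen for another, so the only guide is that compound 2 with a substituent there sits far above compound 1. On that basis compound 3 is expected to stay in the range of compound 2, with a step of a number 3 percentage points lower from compound 2 to compound 3 (within the scatter) that lies within the scatter. The estimate for compound 3 in this assay is 25%, between 0% and 50%.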

Compound 3, a percentage reported as inhibition, at one concentration (the size of the read-out at that concentration, not a potency): 46.6%
Beside the measured number, compound 3's estimate is 21.6 percentage points below it; the measured number falls inside the stated range.
By their numbers in this assay, from the lowest: compound 1; then compound 2; then compound 3.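

In this assay the exchange on the amine nitrogen in a ring gave a further gain (a number 18.6 percentage points higher from compound 2 to compound 3 (beyond the scatter)), so the outcome at this position depends on which group is attached and not only on a group being there. Measured against the unsubstituted compound, the (4-nitrophenyl)sulfonyl group gave the larger gain of the two substituents (a number 67.5 percentage points higher from compound 1 to compound 3 (beyond the scatter)), which places compound 3 highest of the three. No measurement is at hand that bears on why the two groups differ.

The compounds shown do not separate the change from carbonyl to sulfonyl from the change from trifluoromethyl to nitro, as both occur together in this exchange. Also open, going by these compounds, is whether a methylsulfonyl group, or a (4-aminophenyl)sulfonyl group, would hold the inhibition seen with compound 3.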